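Swapping a 4-methylphenyl group for an allyl chain

The source may report more compounds than this note shows. Statements on the series, on what has been measured and on what is new or still open speak of the compounds shown alone.

Compound 1 (`CCc1ccc(NC(=S)N/N=C\c2ccnc3ccccc23)cc1`) gives 35700 nM
Compound 2 (`S=C(N/N=C\c1ccnc2ccccc12)Nc1ccccc1`) gives 118000 nM
Compound 3 (`Cc1ccc(NC(=S)N/N=C\c2ccnc3ccccc23)cc1`) gives 50500 nM

All three numbers come from an ADME assay on RAW264.7 cells (Mus musculus) for cytotoxicity, read by MTT assay, with a stated time of 48 h (a lower number here means that less compound is tolerated, a higher number that more compound is tolerated), and the compounds share one core. Compound 3 belongs to the lower pair of values. Its partner is close, with a 1.4-fold higher number from compound 1 to compound 3 (0.15 log units; within the scatter) in that pair, so the two cannot be told apart. The remaining value stands clearly apart, with a 2.3-fold lower number from compound 2 to compound 3 (0.37 log units; beyond the scatter) on that side.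

The next structure, compound 4 (`C=CCNC(=S)N/N=C\c1ccnc2ccccc12`), carries allyl in place of 4-methylphenyl on an amide-type nitrogen. For the measured compounds named here, no measured step makes this exchange, so the evidence is indirect. The nearest steps only alter the group on the aromatic ring, and both are modest: removing ethyl gave a 3.3-fold higher number from compound 1 to compound 2 (0.52 log units; beyond the scatter) in this small series. Compound 4 also loses the methyl, along with its ring, so going by a 2.3-fold lower number from compound 2 to compound 3 (0.37 log units; beyond the scatter) in reverse, a modest rise is expected. Going by the values given here, the expected change is a 2.2-fold higher number from compound 3 to compound 4 (0.34 log units; beyond the scatter) in this assay with real uncertainty, since no measured compound lacks the ring. Compound 4 is estimated at 110000 nM with an expected range of 40000 nM to 300000 nM for now.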

Compound 4, half-maximal cytotoxic concentration: 105000 nM
The estimate for compound 4 lay 1.0-fold (0.02 log units) above the measured number, within the range that was stated.
By their numbers in this assay, from the lowest: compounds 1 and 3 (each within the scatter of the next); then compounds 4 and 2 (each within the scatter of the next).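

For the compounds shown here, compound 4 is the first compound here without an aromatic ring on the amide-type nitrogen, and replacing 4-methylphenyl with allyl gives a 2.1-fold higher number from compound 3 to compound 4 (0.32 log units; beyond the scatter) in this assay, so the cells tolerate more of the compound. The comparison with the bare phenyl group gives a 1.1-fold lower number from compound 2 to compound 4 (0.05 log units; within the scatter), which means that allyl and phenyl cannot be told apart at this position and that the six-membered aromatic ring can be exchanged for this short open chain with no readable change in tolerance. Replacing 4-ethylphenyl with allyl gives a 2.9-fold higher number from compound 1 to compound 4 (0.47 log units; beyond the scatter), so among these four compounds the two with lower numbers are the two that carry an alkyl group on the ring, while compound 2 and compound 4 both lack one.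

Nothing shown here gives any measured explanation for these differences. Going by these compounds, it also remains open whether the tolerance seen with allyl would hold for a saturated propyl chain, a longer chain or a chain ending in an amine on this nitrogen.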